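Fluorinated oxindole core: chloro to cyano on the triazolyl phenyl

This account rests on a few compounds, and the source may have more. Where it says the series, first, only, none or still open, it means among the compounds named here.

Compound 1 `O=C1Nc2ccccc2/C1=C/c1ccc(-c2cn(-c3cccc(Cl)c3)nn2)cc1` carries a chlorophenyl on the triazole. In an ADME assay on HUVEC cells (Homo sapiens) for inhibition, read by CCK-8 assay, with a stated time of 24 h, in the presence of a further agent that is not named here (a lower number here means a stronger inhibitor, a higher number a weaker inhibitor), compound 1 gives > 20000 nM, which is a limit of the assay and not a number. Compound 2 `N#Cc1cccc(-n2cc(-c3ccc(/C=C4\C(=O)Nc5ccccc54)cc3)nn2)c1` differs by cyano in place of chloro on an aromatic carbon. In this assay compound 2 gives > 20000 nM, again a limit. The step that the two limits leave unreadable from compound 1 to compound 2 is therefore not readable, since both sit at the limit of > 20000 nM in this assay, at which 2 of the 3 values shown sit. Compound 3 `O=C1Nc2ccc(F)cc2/C1=C/c1ccc(-c2cn(-c3cccc(Cl)c3)nn2)cc1` differs from compound 1 by fluoro in place of hydrogen on an aromatic carbon. In this assay, among the measured compounds shown here, compound 3 gives 19400 nM, the only number in the set; the step of an at least 1.0-fold lower number from compound 1 to compound 3 (0.01 log units; that floor lies within the scatter) is within the scatter. Compound 4 `N#Cc1cccc(-n2cc(-c3ccc(/C=C4\C(=O)Nc5ccc(F)cc54)cc3)nn2)c1` is not yet measured; it differs from compound 3 by cyano in place of chloro on an aromatic carbon, the same change as from compound 1 to compound 2. Compounds 1 and 2 both sit at the limit of > 20000 nM in this assay, at which 2 of the 3 values shown sit. On that basis the step of a 1.1-fold higher number from compound 3 to compound 4 (0.05 log units; within the scatter) is expected to be small. Compound 4 is estimated at 22000 nM, between 12000 nM and 45000 nM, with a fair chance that only a limit is reported.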

Compound 4, half-maximal inhibitory concentration: > 20000 nM
Compound 4: no number, only a limit (the forecaster's own chance of this, stated with the estimate: 60%); the middle value is on the limit's open side.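

In this assay compound 4 gives > 20000 nM, which is a limit of the assay and not a number. Going by these compounds, on the fluorinated core, the change from 3-chlorophenyl to 3-cyanophenyl reads as an at least 1.0-fold higher number from compound 3 to compound 4 (0.01 log units; that floor lies within the scatter), so its true size stays unknown, and the steps between two limits cannot be read. The change therefore can be neither confirmed nor ruled out as carrying over from the core of compound 1 to the core of compound 3, because most values rest on a single limit: the limit of > 20000 nM in this assay, at which 3 of the 4 values shown sit.

An amine or a carboxylic acid in place of the chloro is not among the compounds shown. On these data alone, how such groups read in this assay, and whether any of them gives a number on either core, stays open.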